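The source may report more compounds than this note shows. Statements on the series, on what has been measured and on what is new or still open speak of the compounds shown alone.

Measured so far:
- compound 1, `Cc1nc(-c2ccc(Cl)cc2)sc1C(=O)CSc1nc(-c2ccccc2)c(C#N)c(=O)[nH]1`: 83.1%
- compound 2, `COc1ccc(-c2nc(C)c(C(=O)CSc3nc(-c4ccc(OC)cc4)c(C#N)c(=O)[nH]3)s2)cc1`: 80.3%

In a functional assay on U-87MG ATCC cells for antiproliferative activity against U-87 MG (Homo sapiens), read by MTT assay, with a stated time of 48 h, tested at 10 uM (a lower number here means a stronger effect, a higher number a weaker effect of the compound at the concentration tested), compound 1 gives 83.1%, the larger of the two numbers, but its nearest neighbour, compound 2, sits only a small distance lower and that gap lies within the scatter, so no order between the two can be read. For the measured compounds named here, no step between measured compounds that differ in one place is available, and the two values say nothing about the effect of a single substituent.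

Compound 3, `Cc1nc(-c2ccc(Cl)cc2)sc1C(=O)CSc1nc(-c2cccc(Cl)c2)c(C#N)c(=O)[nH]1`, differs from compound 1 by chloro in place of hydrogen on an aromatic carbon; cut one bond further out, the change reads phenyl to 3-chlorophenyl. Nothing in the two measured values gives this change a direction, so the step from compound 1 to compound 3 is expected to be a number 3.1 percentage points lower from compound 1 to compound 3 (within the scatter), that is, none beyond the scatter. Compound 3 is therefore estimated at 80%, within a range from 66% to 94%.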

Compound 3, a percentage reported as activity, at one concentration (the size of the read-out at that concentration, not a potency): 95.2%
Estimate against measurement, compound 3: 15.2 percentage points below, outside the stated range (above it).
By their numbers in this assay, from the lowest: compounds 2 and 1 (each within the scatter of the next); then compound 3.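

In this assay, the change from phenyl to 3-chlorophenyl gives a number 12.1 percentage points higher from compound 1 to compound 3 (beyond the scatter), so adding chloro at this position weakens the effect at the concentration tested. For the compounds shown here, this is the first step that changes only one place, and it shows that this aromatic ring, at the carbon meta to a large group, does not tolerate every replacement of hydrogen without a loss of effect. Nothing shown gives a reason for this step.

Going by these compounds, it remains open whether an amine or a carboxylic acid at the same position would also weaken the effect, leave it unchanged or strengthen it. On these data alone, it is also open whether chloro elsewhere on this ring would give a step of similar size, or whether this step would hold with other groups on the rest of the core of compound 1.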